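The compounds below may be only part of what the source reports. "The series", "measured", "known", "first", "only" and "open" are said of these compounds alone.

Measured compounds:
compound 1 `CCCCCCCCCCCCCCCCC[C@@H](O)C(=O)N[C@@H](CO[C@@H]1O[C@H](CO)[C@@H](O)[C@H](O)[C@H]1O)[C@H](O)/C=C/CC/C=C(\C)CCCCCC` — > 50000 nM
compound 2 `CCCCCCCCCCCCCCC/C=C/[C@@H](O)C(=O)N[C@@H](CO[C@@H]1O[C@H](CO)[C@@H](O)[C@H](O)[C@H]1O)[C@H](O)/C=C/CC/C=C(\C)CCCCCCCC` — > 50000 nM

In a functional assay on HeLa cells (Homo sapiens) for cytotoxicity, read by MTT assay (on this read-out lower numbers stand for stronger inhibition and higher numbers for weaker inhibition), compound 1 gives > 50000 nM, which is a limit of the assay and not a number. In this assay, among the compounds with values here, compound 2 gives > 50000 nM, likewise a limit. the limit of > 50000 nM in this assay, at which 2 of the 2 values shown sit: both values shown sit at that limit, so compound 2 stands level with compound 1, and no step between them can be resolved from these two values.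

Compound 3 is `CCCCCCCCCCCCCCC/C=C/[C@@H](O)C(=O)N[C@@H](CO[C@@H]1O[C@H](CO)[C@@H](O)[C@H](O)[C@H]1O)[C@H](O)/C=C/CC/C=C(\C)CCCCCC`. It differs from compound 2 by hydrogen in place of ethyl on a saturated chain carbon, six bonds along the chain from a double-bonded chain carbon.

With both measured values at the limit, the expected step in this assay is a step that the limit leaves unreadable from compound 2 to compound 3, that is, none beyond the scatter. Compound 3 is therefore estimated at 100000 nM, within 50000 nM to 300000 nM, and is expected most likely to return only a limit again.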

Compound 3, half-maximal inhibitory concentration: > 50000 nM
Compound 3 was reported as a limit; the forecaster's own chance of this, stated with the estimate: 90%; the middle value lies beyond the limit too.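

No step can be read from compound 2 to compound 3, as both results in this assay are limits and not numbers: the limit of > 50000 nM in this assay, at which 3 of the 3 values shown sit.
The compounds shown leave open whether replacing ethyl with hydrogen at this place changes cytotoxicity at all, and whether any chain variant in this series gives a measurable value.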